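A few compounds are considered here, and "the series" means these few. Any claim that something is new, unique, unknown or untested is made for them only; others in the source may bear on it.

Measured in an in vitro ADME assay on microsomes from liver (Homo sapiens) for metabolic stability, using NADPH, with a stated time of 10 min, tested at 0.5 uM; a lower number here means that the compound disappears faster, a higher number that the compound lasts longer:
- Compound 1 `COc1cc(C2CCNCC2)ccc1Nc1ncc2ccc(-c3ccccc3N(C)S(C)(=O)=O)n2n1`: 0.117 h
- Compound 2 `COc1cc(C2CCN(C[C@@H](C)O)CC2)ccc1Nc1ncc2ccc(-c3ccccc3OC)n2n1`: > 0.666 h, a limit of the assay
- Compound 3 `CNC(=O)CN1CCC(c2ccc(Nc3ncc4ccc(-c5ccccc5OC)n4n3)c(OC)c2)CC1`: < 0.2 h, a limit of the assay

For the measured compounds named here, compound 1 holds the only true number among the three, and the other two entries are limits. Compound 4 `COc1cc(C2CCN(CC(N)=O)CC2)ccc1Nc1ncc2ccc(-c3ccccc3N(C)S(C)(=O)=O)n2n1` is derived from compound 1 by one change: carbamoylmethyl in place of hydrogen on an amine nitrogen in a ring.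

Going by the values given here, no measured step adds a chain to this free ring nitrogen, so the evidence is indirect. The closest step is an at least 3.3-fold lower number from compound 2 to compound 3 (0.52 log units; beyond the scatter), with methylcarbamoyl in place of 1-hydroxyethyl on a saturated chain carbon bound to an amine nitrogen in a ring. It suggests that an amide-ended chain need not bring a long half-life, although compound 2 and compound 3 also differ from compound 1 elsewhere in the structure.

In this assay, no change beyond the scatter is therefore expected. The estimated 1.3-fold higher number from compound 1 to compound 4 (0.11 log units; within the scatter) stays small. For compound 4 the estimated half-life is 0.15 h, with an expected range from 0.07 h to 0.35 h.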

Compound 4, half-life: < 0.0834 h
Compound 4 gave a limit, no number; the forecaster's own chance of this, stated with the estimate: 35%; at least 1.7-fold (0.25 log units) between middle value and limit.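

In this assay, compound 4 gives a limit of the assay and not a number: the limit of < 0.0834 h in this assay, at which 1 of the 4 values shown sits. Carbamoylmethyl in place of hydrogen on the amine nitrogen of the six-membered ring can now be read directly on the core of compound 1, and the change gives an at least 1.4-fold lower number from compound 1 to compound 4 (0.14 log units; that floor lies within the scatter). Going by these compounds, the true size of this step remains unknown, so the result shows no gain in half-life from this chain at this position, while a drop beyond the usual scatter remains possible but unproven.

The compounds shown leave open how far the half-life of compound 4 lies under its limit, and whether the step follows from the terminal amide or from the chain itself. A plain ethyl chain or a carboxylic acid on this ring nitrogen would separate those two readings.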